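This account rests on a few compounds, and the source may have more. Where it says the series, first, only, none or still open, it means among the compounds named here.

Compound 1 `NC(=O)c1cnn(-c2ccc(S(N)(=O)=O)cc2)c1N` carries a primary amide and an amino group on a small five-membered ring; in a functional assay on HepG2 cells (Homo sapiens) for cytotoxicity, read by MTT assay, with a stated time of 72 h (a higher number here means a weaker inhibitor, a lower number a stronger inhibitor), compound 1 reaches only the limit of the measurement, > 100000 nM. Compound 2 `NS(=O)(=O)c1ccc(-n2ncc3c(=O)[nH]c(-c4ccccc4)nc32)cc1` closes that ring into a larger fused core bearing an unsubstituted phenyl ring, and in this assay compound 2 gives 77600 nM. Compound 3 `NS(=O)(=O)c1ccc(-n2ncc3c(=O)[nH]c(-c4ccc(F)cc4)nc32)cc1` is the same core with a 4-fluorophenyl group, and in this assay compound 3 gives 2660 nM, the lowest of the two numbers shown; the step of a 29-fold lower number from compound 2 to compound 3 (1.46 log units; beyond the scatter) separates it from compound 2. Compound 4 `NS(=O)(=O)c1ccc(-n2ncc3c(=O)[nH]c(-c4ccc(Cl)cc4)nc32)cc1` differs from compound 3 by chloro in place of fluoro on an aromatic carbon. Among the compounds with values here, only one measured step bears on this exchange, the swap of hydrogen for fluoro in a 29-fold lower number from compound 2 to compound 3 (1.46 log units; beyond the scatter), which was large; no measured pair shows fluoro against chloro. Since both halogens sit at the same position, compound 4 is expected to stay close to compound 3, with a step of a 1.3-fold lower number from compound 3 to compound 4 (0.12 log units; within the scatter) estimated. The estimate for compound 4 is therefore 2000 nM, within a range from 600 nM to 8000 nM.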

Compound 4, half-maximal inhibitory concentration: 23900 nM
Compound 4: the middle estimate sits 12-fold (1.08 log units) below what was measured, and the stated range ends below it.
By their numbers in this assay, from the lowest: compound 3; then compound 4; then compound 2. At a limit, above all of these: compound 1.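

The halogens are not interchangeable at this position: in this assay the change from 4-fluorophenyl to 4-chlorophenyl gives a 9.0-fold higher number from compound 3 to compound 4 (0.95 log units; beyond the scatter), so one exchanged atom moves the read-out clearly. Chloro still gives a lower number than hydrogen, a 3.2-fold lower number from compound 2 to compound 4 (0.51 log units; beyond the scatter), but that step is smaller than the one for fluoro, a 29-fold lower number from compound 2 to compound 3 (1.46 log units; beyond the scatter), so a halogen here does not by itself bring the full drop seen with compound 3. Nothing measured here gives a reason for the gap between fluoro and chloro.

The compounds shown leave open where a bromo, methyl, methoxy or amino group at this position would fall relative to hydrogen, fluoro and chloro. They also leave open whether fluoro and chloro would differ in the same way on another core, since compound 2, compound 3 and compound 4 all share one.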